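The source may report more compounds than this note shows. Statements on the series, on what has been measured and on what is new or still open speak of the compounds shown alone.

Measured in a functional assay on MCF7 cells (Homo sapiens) for antiproliferative activity, read by MTT assay, with a stated time of 48 h; a higher number here means a weaker inhibitor, a lower number a stronger inhibitor:
- compound 1 `N=C(N)N/N=C(/C=C/c1ccccc1)c1ccccc1`: 17000 nM
- compound 2 `N=C(N)N/N=C(/C=C/c1cccc(F)c1)c1ccccc1`: 16000 nM
- compound 3 `N=C(N)N/N=C(/C=C/c1ccccc1)c1ccc(Br)cc1`: 90 nM

Compound 3 stands lowest of the three, with both other values far above it. Compound 4 `COc1ccc(C(/C=C/c2ccccc2)=N\NC(=N)N)cc1` differs from it by one change, methoxy in place of bromo on an aromatic carbon.

The closest evidence is a 190-fold lower number from compound 1 to compound 3 (2.28 log units; beyond the scatter), which shows what adding the bromo gave. The fluoro step, a 1.1-fold lower number from compound 1 to compound 2 (0.03 log units; within the scatter), says little here. Within the data shown here, no measured step covers methoxy, so the size remains uncertain. Part of the gain seen for compound 3 is expected to be lost in this assay, and the expected step is a 17-fold higher number from compound 3 to compound 4 (1.22 log units; beyond the scatter). For compound 4 the estimated value is 1500 nM, with an expected range of 150 nM to 15000 nM.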

Compound 4, half-maximal inhibitory concentration: 13000 nM
The estimate for compound 4 lay 8.7-fold (0.94 log units) below the measured number; low and high end bracket the measured number.
By their numbers in this assay, from the lowest: compound 3; then compounds 4, 2 and 1 (each within the scatter of the next).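

In this assay the gain at this position belongs to bromo alone among the groups shown: methoxy gives a 140-fold higher number from compound 3 to compound 4 (2.16 log units; beyond the scatter) and so loses it. With a 1.3-fold lower number from compound 1 to compound 4 (0.12 log units; within the scatter) as the step from hydrogen, within the scatter, a substituent at this place does not by itself bring the gain. Nothing measured here accounts for the difference between bromo and methoxy.

From the compounds shown here alone, whether chloro or iodo would keep the gain of bromo remains open. So does whether an amine or a carboxylic acid at this place would behave like methoxy.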